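Hydroxyazole amides: two readings that lie level, pyrazole analogue pending

A few compounds are considered here, and "the series" means these few. Any claim that something is new, unique, unknown or untested is made for them only; others in the source may bear on it.

Two hydroxyazole amides have been run in an assay on isolated protein for inhibition of mitogen-activated protein kinase kinase kinase 14 (Homo sapiens), read by ADP-Glo, with a stated time of 60 min, tested at 100 uM, in the presence of a further agent that is not named here; on this read-out lower numbers stand for less inhibition and higher numbers for more inhibition at the one concentration tested (going by the name of the read-out). Compound 1 `O=C(Nc1cccc(C(F)(F)F)c1)c1nsnc1O` gives -1.1%, and compound 2 `O=C(Nc1cc(C(F)(F)F)cc(C(F)(F)F)c1)c1n[nH]nc1O` gives -9.5%. Compound 2 stands lowest of the two numbers; its nearest neighbour is compound 1, whose number is higher by an amount within the scatter, so the two read alike and neither shows inhibition at the concentration tested. Within the data shown here, no step between measured compounds is available.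

Compound 3 `Cn1cc(C(=O)Nc2cc(C(F)(F)F)cc(C(F)(F)F)c2)c(O)n1` is to be measured in this assay. It differs from compound 2 in one place: 3-hydroxy-1-methyl-1H-pyrazol-4-yl in place of 5-hydroxy-2H-1,2,3-triazol-4-yl on a carbonyl carbon. Compound 2 sits at -9.5% and nothing in the pair points to movement. Compound 3 is therefore expected to stay near the floor of the read-out. The expected step is a number 9.5 percentage points higher from compound 2 to compound 3 (within the scatter), none beyond the scatter in either direction. The estimate for compound 3 is 0%, with a range from -15% to 15%.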

Compound 3, a percentage reported as inhibition, at one concentration (the size of the read-out at that concentration, not a potency): 7.23%
The estimate for compound 3 lay 7.2 percentage points below the measured number; measured number inside the range.
By their numbers in this assay, from the lowest: compounds 2, 1 and 3 (each within the scatter of the next, the first and the last beyond it).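

In this assay, the place on the carbonyl carbon now shows a step beyond the scatter: 3-hydroxy-1-methyl-1H-pyrazol-4-yl in place of 5-hydroxy-2H-1,2,3-triazol-4-yl gives a number 16.7 percentage points higher from compound 2 to compound 3 (beyond the scatter). The step is modest, and compound 3 at 7.23% remains a small reading at the one concentration tested, so this position responds to the change without yet giving clear inhibition. Nothing available bears on why the number moves.

The change alters the ring hetero atoms and the hydrogen-bond donor count and adds a methyl group all at once, and this single pair does not separate those differences. Going by these compounds, whether an ethyl group or a longer chain in place of that methyl moves the number further remains open.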